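The source may hold more compounds than are shown below. What is called first, only, known or untested is meant among the compounds shown, and "the series" means these compounds.

Measured compounds:
compound 1 `Nc1cc(N)c2nc(-c3ccccc3)c(Sc3ccc(F)cc3)nc2c1` — 22900 nM
compound 2 `CCOC(=O)[C@H](CCC(=O)O)NC(=O)c1ccc(Oc2nc3cc(N)cc(N)c3nc2-c2ccccc2)cc1` — 35500 nM

Both numbers come from a functional assay on OVCAR-4 cells (Homo sapiens) for inhibition, read by sulforhodamine B assay, with a stated time of 48 h; a lower number here means a stronger inhibitor of growth, a higher number a weaker inhibitor of growth. Compound 1 and compound 2 lie within the scatter of each other, so the two cannot be separated on these data; both are weak.

Compound 3 `Nc1cc(N)c2nc(-c3ccccc3)c(NCc3ccc(F)cc3)nc2c1` is unmeasured. It differs from compound 1 in one place: (4-fluorobenzyl)amino in place of (4-fluorophenyl)sulfanyl on an aromatic carbon. For the measured compounds named here, no measured pair shows the effect of such a change, so the step in this assay is expected to be small, none beyond the scatter in either direction.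

For compound 3 the expected value is 20000 nM, with a range of 6000 nM to 70000 nM, an estimated step of a 1.1-fold lower number from compound 1 to compound 3 (0.06 log units; within the scatter).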

Compound 3, concentration for 50% growth inhibition: 1700 nM
Compound 3: middle estimate off by 12-fold (1.07 log units), on the high side, outside the stated range (below it).
By their numbers in this assay, from the lowest: compound 3; then compounds 1 and 2 (each within the scatter of the next).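

Within this assay the aromatic carbon next to the ring nitrogen is not indifferent to its substituent: (4-fluorobenzyl)amino in place of (4-fluorophenyl)sulfanyl brings a 13-fold lower number from compound 1 to compound 3 (1.13 log units; beyond the scatter) on an otherwise unchanged core. The entering group differs in its link to the ring and carries a hydrogen-bond donor that the leaving group lacks. Nothing available explains the gain.

Open, from the compounds shown here alone, is whether the amine nitrogen or the added methylene carries the step. (4-Fluorophenyl)amino and (4-fluorobenzyl)sulfanyl at this position would separate the two.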